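This account rests on a few compounds, and the source may have more. Where it says the series, first, only, none or still open, it means among the compounds named here.

Among the measured compounds shown here, compound 2 `O=C(/C=C/c1cccc(O)c1)c1cc(O)c(O)c([N+](=O)[O-])c1` gives 140 nM in an assay for inhibition of Catechol O-methyltransferase (Rattus norvegicus), read by fluorescence and spectrophotometry (on this read-out higher numbers stand for weaker inhibition and lower numbers for stronger inhibition), the lower of the two numbers so far, though the gap to compound 1 lies within the scatter. Compound 1 `O=C(/C=C/c1ccsc1)c1cc(O)c(O)c([N+](=O)[O-])c1` gives 230 nM in this assay. For the measured compounds named here, the one measured step, a 1.6-fold lower number from compound 1 to compound 2 (0.22 log units; within the scatter), was within the scatter. Compound 3 `Cn1cc(/C=C/C(=O)c2cc(O)c(O)c([N+](=O)[O-])c2)cn1` differs from compound 2 by 1-methyl-1H-pyrazol-4-yl in place of 3-hydroxyphenyl on a double-bonded chain carbon bound to a double-bonded chain carbon. This is the same place varied in that step, so only a small change, if any, beyond the scatter is expected in this assay. Compound 3 is expected near 200 nM, within 80 nM to 500 nM. The expected step is a 1.4-fold higher number from compound 2 to compound 3 (0.15 log units; within the scatter).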

Compound 3, half-maximal inhibitory concentration: 290 nM
Beside the measured number, compound 3's estimate is 1.5-fold (0.16 log units) below it; the measured number falls inside the stated range.
By their numbers in this assay, from the lowest: compounds 2, 1 and 3 (each within the scatter of the next, the first and the last beyond it).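

In this assay, among the compounds shown here, the step of a 2.1-fold higher number from compound 2 to compound 3 (0.32 log units; beyond the scatter) is the first at this position to pass beyond the scatter, though only modestly. The step of a 1.3-fold higher number from compound 1 to compound 3 (0.10 log units; within the scatter) stays within it, so the thiophen-3-yl of compound 1 cannot be told apart from the 1-methyl-1H-pyrazol-4-yl of compound 3. Nothing available explains the modest loss from 3-hydroxyphenyl. This change alters ring size and hydrogen-bond donor count together, and the two cannot be separated here. Going by these compounds, how an amine or a carboxylic acid at this place would read remains open.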